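Trimming One Carbon From a Difluorinated Alcohol

This account rests on a few compounds, and the source may have more. Where it says the series, first, only, none or still open, it means among the compounds named here.

Compound 1, `CCCC(F)CO`, gives 0.87 in a physicochemical assay for lipophilicity, read by NMR; a higher number here means a more lipophilic compound, a lower number a more polar compound.
Compound 2, `CCCC(F)(F)CO`, gives 1.25 in this assay.
Compound 3, `OCCCC(F)(F)CF`, gives 0.58 in this assay.

Compound 2 stands highest of the three numbers in this assay. Compound 1 is the nearest to it, lower by a step beyond the scatter, and compound 3 is the furthest, also lower by more than the scatter. Among the compounds with values here, only one of these pairs differs in a single place: a number 0.38 log units higher from compound 1 to compound 2 (beyond the scatter), a modest rise when fluoro takes the place of hydrogen.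

Compound 4, `CCC(F)(F)CO`, differs from compound 2 by hydrogen in place of methyl on a saturated chain carbon, three bonds along the chain from two fluorine atoms. Within the data shown here, none of the measured pairs shows a change of this kind; the one recorded step, a number 0.38 log units higher from compound 1 to compound 2 (beyond the scatter), concerns the addition of a fluorine atom rather than the loss of a carbon, so it does not bear directly on this change. Drawing only on the count of what leaves and what enters, a downward step of modest size is expected here, a number 0.50 log units lower from compound 2 to compound 4 (beyond the scatter), beyond the usual scatter but not large. For compound 4 the estimate in this assay is therefore 0.75, with a likely range from 0.45 to 1.05.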

Compound 4, partition coefficient: 0.67
Compound 4: middle estimate off by 0.08 log units, on the high side; low and high end bracket the measured number.
By their numbers in this assay, from the lowest: compounds 3, 4 and 1 (each within the scatter of the next); then compound 2.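

Shortening the chain at this position, from ethyl to methyl on a saturated chain carbon, three bonds along the chain from two fluorine atoms, gives a number 0.58 log units lower from compound 2 to compound 4 (beyond the scatter) in this assay. Within the data shown here, this is the first direct reading of what chain length does in this set, since the only earlier step between compounds differing in one place, a number 0.38 log units higher from compound 1 to compound 2 (beyond the scatter), changed the fluorine count and left the chain as it was. It shows that the loss of a single carbon, with both fluorine atoms and the alcohol kept, is enough to carry the number beyond the scatter, by a step that is modest in size, as the fluorine step was, but opposite in direction, and nothing measured here accounts for why the number falls.

From the compounds shown here alone, what stays open is whether a longer chain, such as propyl or butyl at this same position, would extend the trend or level it off. Going by these compounds, it is also open whether the same trimming would give a step of similar size if an amine or a carboxylic acid stood in place of the alcohol, or if only one fluorine atom were present.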